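A few compounds are considered here, and "the series" means these few. Any claim that something is new, unique, unknown or untested is made for them only; others in the source may bear on it.

Measured so far:
- Compound 1 `Cc1c(Cc2ccccc2)c(=O)oc2cc(OCC(O)CNc3ccccc3)ccc12`: in an ADME assay on A549 cells (Homo sapiens) for cytotoxicity, read by CellTiter-Glo (a lower number here means that less compound is tolerated, a higher number that more compound is tolerated), compound 1 gives > 100000 nM, which is a limit of the assay.
- Compound 2 `Cc1c(Cc2ccccc2)c(=O)oc2cc(OCC(O)CNc3ccc(Br)cc3)ccc12`: in this assay compound 2 gives > 100000 nM, again a limit of the assay.
- Compound 3 `Cc1c(Cc2ccccc2)c(=O)oc2cc(OCC(O)CNC3CCOCC3)ccc12`: in this assay compound 3 gives 38200 nM.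

Within the data shown here, compound 3 thus holds the only actual number in this assay; the other two values sit at the limit of > 100000 nM in this assay, at which 2 of the 3 values shown sit. The step from compound 1 to compound 2 is a step that the two limits leave unreadable from compound 1 to compound 2. Both measured steps into compound 3 run the same way: an at least 2.6-fold lower number from compound 1 to compound 3 (0.41 log units; beyond the scatter) and an at least 2.6-fold lower number from compound 2 to compound 3 (0.41 log units; beyond the scatter).

Compound 4 `Cc1ccc2nc(NCC(O)COc3ccc4c(C)c(Cc5ccccc5)c(=O)oc4c3)sc2c1` differs from compound 3 by 6-methyl-1,3-benzothiazol-2-yl in place of oxan-4-yl on an amine nitrogen. The measured steps show that oxan-4-yl in place of an aromatic group on the amine nitrogen lowered the number; compound 4 reverses that direction, though with a bicyclic heteroaromatic group rather than phenyl or 4-bromophenyl. A higher number than compound 3 is therefore expected, quite possibly back at the limit. The expected step from compound 3 to compound 4 is a 1.8-fold higher number from compound 3 to compound 4 (0.26 log units; within the scatter). Compound 4 is estimated at 70000 nM, within 25000 nM to 150000 nM.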

Compound 4, half-maximal cytotoxic concentration: > 100000 nM
Compound 4: no number, only a limit (the forecaster's own chance of this, stated with the estimate: 45%); at least 1.4-fold (0.15 log units) between middle value and limit.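

Compound 4 gives > 100000 nM in this assay, which is a limit of the assay and not a number. The step of an at least 2.6-fold higher number from compound 3 to compound 4 (0.41 log units; beyond the scatter) shows that a fused aromatic group, 6-methyl-1,3-benzothiazol-2-yl, sits with phenyl and 4-bromophenyl on this amine nitrogen, not with oxan-4-yl, while the steps from compound 1 and compound 2 to compound 4 cannot be read. Among the groups shown on this nitrogen, only the oxan-4-yl of compound 3 gives a number: the limit of > 100000 nM in this assay, at which 3 of the 4 values shown sit.

On these data alone, how the three aromatic groups differ from one another remains open, with all of them at the limit. As far as these compounds go, it is also open whether the lower number needs the ring oxygen of oxan-4-yl, which a cyclohexyl group on the same nitrogen would address, or holds for an open chain such as 2-methoxyethyl.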